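The source may hold more compounds than are shown below. What is called first, only, known or untested is meant among the compounds shown, and "the series" means these compounds.

In a functional assay on DU-145 cells (Homo sapiens) for antiproliferative activity, read by MTT assay, with a stated time of 72 h (on this read-out higher numbers stand for weaker inhibition and lower numbers for stronger inhibition), the measured compounds are:
compound 1 `COc1cccc(N(C)S(=O)(=O)C2CC3OC2C(c2ccc(NC(=O)CCCCCCC(=O)O)cc2)=C3c2ccc(O)cc2)c1` gives 62200 nM
compound 2 `CN(c1ccc(Cl)cc1)S(=O)(=O)C1CC2OC1C(c1ccc(NC(=O)CCCCCCC(=O)O)cc1)=C2c1ccc(O)cc1` gives 72100 nM
compound 3 `CCN(c1ccc(C)cc1)S(=O)(=O)C1CC2OC1C(c1ccc(NC(=O)CCCCCCC(=O)O)cc1)=C2c1ccc(O)cc1` gives 53500 nM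

Compound 3 is not separated from the other two, as a 1.2-fold lower number from compound 1 to compound 3 (0.07 log units; within the scatter) and a 1.3-fold lower number from compound 2 to compound 3 (0.13 log units; within the scatter) show. Compound 4 `CCN(c1ccc(Cl)cc1)S(=O)(=O)C1CC2OC1C(c1ccc(NC(=O)CCCCCCC(=O)O)cc1)=C2c1ccc(O)cc1` keeps the ethyl group of compound 3 and differs from it by chloro in place of methyl on an aromatic carbon, para to a large group.

For the measured compounds named here, no measured step isolates this change. The closest is a 1.3-fold lower number from compound 2 to compound 3 (0.13 log units; within the scatter), which links 4-chlorophenyl and 4-methylphenyl but also exchanges methyl for ethyl. a 1.2-fold higher number from compound 1 to compound 2 (0.06 log units; within the scatter) also stays small. No shift beyond the scatter is therefore expected in this assay, and the expected step is a 1.2-fold higher number from compound 3 to compound 4 (0.06 log units; within the scatter). For compound 4 the estimated value is 62000 nM, with an expected range of 35000 nM to 105000 nM.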

Compound 4, half-maximal inhibitory concentration: 42100 nM
The estimate for compound 4 lay 1.5-fold (0.17 log units) above the measured number, and the stated range covers the measured number.
By their numbers in this assay, from the lowest: compounds 4, 3, 1 and 2 (each within the scatter of the next).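

In this assay the exchange of 4-methylphenyl for 4-chlorophenyl, now seen alone with the ethyl group held fixed, gives a 1.3-fold lower number from compound 3 to compound 4 (0.10 log units; within the scatter) and does not separate chloro from methyl at this position. Methyl in place of hydrogen on the saturated chain carbon bound to the sulfonamide nitrogen gives a 1.7-fold lower number from compound 2 to compound 4 (0.23 log units; within the scatter) and the replacement of the whole amino group gives a 1.5-fold lower number from compound 1 to compound 4 (0.17 log units; within the scatter), so neither moves the number beyond the scatter. No evidence bears on these steps.

From the compounds shown here alone, whether an amine or a carboxylic acid in place of the chloro, or a longer chain in place of the ethyl, would shift the number stays open.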